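The source may hold more compounds than are shown below. What is called first, only, known or untested is meant among the compounds shown, and "the series" means these compounds.

Three compounds share one core and differ only in the aromatic group on the amine nitrogen. In a functional assay on MCF7 cells (Homo sapiens) for cytotoxicity, read by MTT assay, with a stated time of 48 h (a higher number here means a weaker inhibitor, a lower number a stronger inhibitor), compound 1 `O=C(/C=C\Nc1ccc2[nH]ccc2c1)c1c(-c2ccc(Cl)cc2)nc2ccccn12` gives 7130 nM, compound 2 `O=C(/C=C\Nc1ccc2cc[nH]c2c1)c1c(-c2ccc(Cl)cc2)nc2ccccn12` gives 9600 nM and compound 3 `O=C(/C=C\Nc1cnc2ccccc2c1)c1c(-c2ccc(Cl)cc2)nc2ccccn12` gives 18900 nM. Compound 3 is level with its nearest neighbour, with a 2.0-fold higher number from compound 2 to compound 3 (0.29 log units; within the scatter). Its furthest gap, a 2.7-fold higher number from compound 1 to compound 3 (0.42 log units; beyond the scatter), is a modest but real difference.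

Compound 4 `O=C(/C=C\Nc1ccc2ncccc2c1)c1c(-c2ccc(Cl)cc2)nc2ccccn12` changes one detail of compound 3: quinolin-6-yl in place of quinolin-3-yl on an amine nitrogen. This is quinolin-6-yl in place of quinolin-3-yl on an amine nitrogen, so the two have the same atoms, joined differently. The closest measured parallel is a 1.3-fold higher number from compound 1 to compound 2 (0.13 log units; within the scatter), where 1H-indol-6-yl replaces 1H-indol-5-yl and the attachment point moves in a similar way. Within the data shown here, that is only one example, and it is small. The other two steps, a 2.7-fold higher number from compound 1 to compound 3 (0.42 log units; beyond the scatter) and a 2.0-fold higher number from compound 2 to compound 3 (0.29 log units; within the scatter), exchange one kind of group for another, so they bear less directly on this change. Among the measured compounds shown here, no measured compound carries quinolin-6-yl, so the direction remains uncertain, and no step beyond the scatter is expected in this assay. The expected change is a 1.5-fold lower number from compound 3 to compound 4 (0.16 log units; within the scatter). The estimated value for compound 4 is 13000 nM, with an expected range from 5500 nM to 30000 nM.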

Compound 4, half-maximal inhibitory concentration: 22800 nM
Compound 4: middle estimate off by 1.8-fold (0.24 log units), on the low side; low and high end bracket the measured number.
By their numbers in this assay, from the lowest: compounds 1, 2, 3 and 4 (each within the scatter of the next, the first and the last beyond it).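

Moving the attachment point on the quinoline gives a 1.2-fold higher number from compound 3 to compound 4 (0.08 log units; within the scatter) in this assay, so on this amine nitrogen quinolin-3-yl and quinolin-6-yl cannot be told apart, and a swap of attachment point within one ring system has now stayed within the scatter for both the indoles and the quinolines. Compound 4 also sharpens the contrast between the two ring systems, with a 2.4-fold higher number from compound 2 to compound 4 (0.38 log units; beyond the scatter) and a 3.2-fold higher number from compound 1 to compound 4 (0.50 log units; beyond the scatter), both modest, so here the quinoline reads above either indole, although compound 3 remains the exception with its step from compound 2 within the scatter. No measurement shown here explains these differences between the indoles and the quinolines.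

The compounds shown leave open how a single ring, such as a plain phenyl or a pyridin-3-yl, would compare on this amine nitrogen with the two-ring groups tested so far. Also open is what a phenyl carrying a carboxylic acid or a short amine chain would do here, since every group shown is an unsubstituted indole or quinoline.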